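Ring Expansion on the Sulfonyl and Liver Cell Tolerance

The source may hold more compounds than are shown below. What is called first, only, known or untested is meant among the compounds shown, and "the series" means these compounds.

Compound 1 `CN1CCN(S(=O)(=O)c2ccc(-c3ccc4nncc(Nc5ccc(OCc6cccc(F)c6)c(Cl)c5)c4c3)cc2)CC1` in a toxicity assay on HepG2 cells (Homo sapiens) for cytotoxicity, read by MTT assay, with a stated time of 48 h (a higher number here means that more compound is tolerated, a lower number that less compound is tolerated), gives > 15 uM, which is a limit of the assay and not a number. Compound 2 `CN1CCN(S(=O)(=O)c2ccc(-c3ccc4c(Nc5ccc(OCc6cccc(F)c6)c(Cl)c5)cnnc4c3)cc2)CC1` in this assay gives > 15 uM, again a limit of the assay. Compound 3 `CN1CCCN(S(=O)(=O)c2ccc(-c3ccc4c(Nc5ccc(OCc6cccc(F)c6)c(Cl)c5)cnnc4c3)cc2)CC1` in this assay gives 15 uM.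

Compounds 1 and 2 are built from the same atoms joined differently, and the difference between their two cores is not broken down here. Compound 3 differs from compound 2 in a single place: 4-methyl-1,4-diazepan-1-yl in place of 4-methylpiperazin-1-yl on a sulfonyl sulfur. The step that this change made in this assay reads a number no higher from compound 2 to compound 3 (the limit leaves the size open). From the compounds shown here alone, its size stays open because compound 2 stands at the limit of > 15 uM in this assay, at which 2 of the 3 values shown sit.

Compound 4 `CN1CCCN(S(=O)(=O)c2ccc(-c3ccc4nncc(Nc5ccc(OCc6cccc(F)c6)c(Cl)c5)c4c3)cc2)CC1` has not yet been measured. For the measured compounds named here, it differs from compound 1 by 4-methyl-1,4-diazepan-1-yl in place of 4-methylpiperazin-1-yl on a sulfonyl sulfur, the same change at the same place as the one that separates compound 3 from compound 2. Among the compounds shown this change occurs twice, once measured and once not.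

The one measured case of this change did not reveal a step beyond the scatter, and compound 1 itself sits at the limit of the assay. On that basis the step from compound 1 to compound 4 in this assay is expected to be a number no higher from compound 1 to compound 4 (the limit leaves the size open). Compound 4 is therefore estimated to give 15 uM in this assay, with a likely range from 8 uM to 30 uM, and a fair chance that the assay again reports only its limit.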

Compound 4, half-maximal toxic concentration: 7.3 uM
For compound 4 the middle estimate is 2.1-fold (0.31 log units) above the measured one; the measured number lies below the stated range.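

In this assay, replacing 4-methylpiperazin-1-yl with 4-methyl-1,4-diazepan-1-yl on a sulfonyl sulfur gives an at least 2.0-fold lower number from compound 1 to compound 4 (0.31 log units; beyond the scatter), so on the core of compound 1 this change has a readable effect that lies beyond the scatter. Set beside the same change on the core of compound 2, the two steps compare as follows: the same change on two cores in this assay, a number no higher (the limit leaves the size open) from compound 2 to compound 3 and an at least 2.0-fold lower number (0.31 log units; beyond the scatter) from compound 1 to compound 4; the limit leaves it open whether they differ. From the compounds shown here alone, the two cores therefore agree in that neither step reads as a rise, but this does not show that the change carries the same size from one core to the other, since the true size of each step stays unknown because both starting compounds stand at one limit: the limit of > 15 uM in this assay, at which 2 of the 4 values shown sit.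

The compounds shown leave open where compound 1 and compound 2 would fall if either gave a number rather than a limit, and so how large either step really is. They also leave open whether the lower number follows from the seven-membered ring itself, or whether a morpholine on the sulfonyl sulfur, or a longer chain in place of the methyl on the ring nitrogen, would read differently on these two cores.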